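This account rests on a few compounds, and the source may have more. Where it says the series, first, only, none or still open, it means among the compounds named here.

Among the measured compounds shown here, compound 2 `CCOC(=O)c1cnc(NN2C(=O)C=C(C)C2=O)nc1C(F)(F)C(F)(F)F` and compound 1 `CCOC(=O)c1cnc(N(C(=O)NC)N2C(=O)C=C(C)C2=O)nc1C(F)(F)F` share a core and differ in more than one place, so no single step links them. In a functional assay on Jurkat cells (Homo sapiens) for inhibition (on this read-out higher numbers stand for weaker inhibition and lower numbers for stronger inhibition), compound 2 gives 200 nM, the lower of the two numbers recorded, while compound 1 gives 590 nM in this assay, a gap that lies beyond the usual scatter. Compound 3 `CCOC(=O)c1cnc(NN2C(=O)C=C(C)C2=O)nc1C1CC1` has not yet been measured; it carries cyclopropyl in place of 1,1,2,2,2-pentafluoroethyl on an aromatic carbon. For the measured compounds named here, nothing measured so far shows what this exchange does in this assay, so the expectation rests only on the structural change itself. Compound 3 is expected to give a somewhat higher number than compound 2, a step of a 2.5-fold higher number from compound 2 to compound 3 (0.40 log units; beyond the scatter) that may reach slightly beyond the scatter toward weaker inhibition. The estimate for compound 3 in this assay is 500 nM, with a plausible range from 150 nM to 2000 nM.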

Compound 3, half-maximal inhibitory concentration: 1500 nM
The estimate for compound 3 lay 3.0-fold (0.48 log units) below the measured number; low and high end bracket the measured number.
By their numbers in this assay, from the lowest: compound 2; then compound 1; then compound 3.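

In this assay, putting cyclopropyl in place of 1,1,2,2,2-pentafluoroethyl on the aromatic carbon next to the ring nitrogen and ortho to the ethoxycarbonyl group gives a 7.5-fold higher number from compound 2 to compound 3 (0.88 log units; beyond the scatter). Among the compounds shown here, this is the first comparison here that differs in one place only, and it shows that inhibition in these cells responds to the group at this position, which the pair of compound 1 and compound 2 could not show. Nothing at hand accounts for this weakening of inhibition.

This single pair does not tell whether the fluorine atoms, the chain or the ring decides the outcome; an ethyl or a tert-butyl group on the same carbon would bear on that question. The compounds shown also offer no pair that isolates the other differences between compound 1 and compound 2.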